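A few compounds are considered here, and "the series" means these few. Any claim that something is new, unique, unknown or untested is made for them only; others in the source may bear on it.

Compounds measured so far in a functional assay on SF-268 cells (Homo sapiens) for inhibition, read by sulforhodamine B assay, with a stated time of 48 h, tested at 10 uM; on this read-out lower numbers stand for less inhibition and higher numbers for more inhibition at the one concentration tested (going by the name of the read-out):

Compound 1 `Brc1cn2ccnc2c(-c2ccc3ncn(C4CCCCC4)c3c2)n1` gives 17.1%.
Compound 2 `O=Cc1ccc(-c2cn3ccnc3c(-c3ccc4ncn(C5CCCCC5)c4c3)n2)cc1` gives 27.1%.
Compound 3 `Brc1ccc(-c2cn3ccnc3c(-c3ccc4ncn(C5CCCCC5)c4c3)n2)cc1` gives 15.5%.

On these numbers compound 3 stands lowest of the three, though one of its two gaps is only a number 1.6 percentage points lower from compound 1 to compound 3 (within the scatter), while the other is a number 11.6 percentage points lower from compound 2 to compound 3 (beyond the scatter). Compound 4 `Fc1ccccc1-c1cn2ccnc2c(-c2ccc3ncn(C4CCCCC4)c3c2)n1` is the next compound to be measured. It differs from compound 3 in one place: 2-fluorophenyl in place of 4-bromophenyl on an aromatic carbon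

Among the compounds with values here, two measured steps touch the same region. Replacing bromo on an aromatic carbon with 4-bromophenyl gave a number 1.6 percentage points lower from compound 1 to compound 3 (within the scatter), and swapping formyl for bromo on that phenyl ring gave a number 11.6 percentage points lower from compound 2 to compound 3 (beyond the scatter). Both are small, and the larger of them comes from a change of a substituent on the phenyl ring, which is also what the step to compound 4 does. Within the data shown here, no measured compound carries 2-fluorophenyl, so the direction cannot be read from the data, and the expectation is a step of a number 2.5 percentage points higher from compound 3 to compound 4 (within the scatter), which is no step beyond the scatter. Compound 4 is therefore estimated at 18%, with a range from 7% to 30%.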

Compound 4, a percentage reported as inhibition, at one concentration (the size of the read-out at that concentration, not a potency): 6.04%
The estimate for compound 4 lay 12 percentage points above the measured number; the measured number lies below the stated range.
By their numbers in this assay, from the lowest: compounds 4, 3, 1 and 2 (each within the scatter of the next, the first and the last beyond it).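

In this assay, 2-fluorophenyl on this aromatic carbon gives a number 11.1 percentage points lower from compound 1 to compound 4 (beyond the scatter) and a number 21.1 percentage points lower from compound 2 to compound 4 (beyond the scatter) and so separates from both bromo and 4-formylphenyl, whereas 4-bromophenyl in the same place did not separate from bromo. Against 4-bromophenyl itself, the same group gives a number 9.5 percentage points lower from compound 3 to compound 4 (within the scatter) and so the two substituted phenyl rings cannot be told apart, even though only 2-fluorophenyl clears the scatter from bromo. Nothing available explains this result.

Compound 3 and compound 4 differ in both the halogen and its place on the phenyl ring, so the compounds shown cannot say which of the two matters. From the compounds shown here alone, how this aromatic carbon would respond to a phenyl ring carrying an amine or a carboxylic acid also remains open.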